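The source may hold more compounds than are shown below. What is called first, only, known or untested is meant among the compounds shown, and "the series" means these compounds.

In a functional assay on DU-145 cells (Homo sapiens) for inhibition, read by MTT assay, with a stated time of 72 h (a higher number here means a weaker inhibitor, a lower number a stronger inhibitor), compound 1 `O=C(O)CCCCCCC(=O)Nc1ccc(C2=C(c3ccc(O)cc3)C3CC(S(=O)(=O)Oc4ccccc4C(F)(F)F)C2O3)cc1` reads > 100000 nM as a limit of the assay, not a number. Within the data shown here, compound 2 `Cc1ccc(OS(=O)(=O)C2CC3OC2C(c2ccc(NC(=O)CCCCCCC(=O)O)cc2)=C3c2ccc(O)cc2)cc1` gives 80800 nM as the only number so far. Compound 3 `O=C(O)CCCCCCC(=O)Nc1ccc(C2=C(c3ccc(O)cc3)C3CC(S(=O)(=O)Oc4ccc(C(F)(F)F)cc4)C2O3)cc1` differs from compound 2 by trifluoromethyl in place of methyl on an aromatic carbon, para to a large group (trifluoromethyl in place of methyl on an aromatic carbon). Among the measured compounds shown here, the one measured step on this ring is an at least 1.2-fold lower number from compound 1 to compound 2 (0.09 log units; that floor lies within the scatter) and so in this assay no step beyond the scatter is expected for this change. The expected size is a 1.1-fold higher number from compound 2 to compound 3 (0.02 log units; within the scatter) as an estimate. For compound 3 the estimated value is 85000 nM (expected range 45000 nM to 100000 nM).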

Compound 3, half-maximal inhibitory concentration: 77000 nM
Compound 3: the middle estimate sits 1.1-fold (0.04 log units) above what was measured; low and high end bracket the measured number.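

In this assay, trifluoromethyl in place of methyl on the aromatic carbon gives a 1.0-fold lower number from compound 2 to compound 3 (0.02 log units; within the scatter), so this change at this position stays within the scatter. Moving the trifluoromethyl, 4-(trifluoromethyl)phenyl in place of 2-(trifluoromethyl)phenyl, gives an at least 1.2-fold lower number from compound 1 to compound 3 (0.11 log units; that floor lies within the scatter), and that floor also stays within the scatter. The reading for compound 1 is a limit of the assay and not a number, so this step has no upper bound: the limit of > 100000 nM in this assay, at which 1 of the 3 values shown sits.

Still open, going by these compounds, is whether an amine or a nitrile on this phenyl ring would move the number beyond the scatter.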